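Trifluoromethyl for fluoro on the aryl of compound 2

A few compounds are considered here, and "the series" means these few. Any claim that something is new, unique, unknown or untested is made for them only; others in the source may bear on it.

Compound 2 `Oc1cc(C(F)(F)F)ccc1-c1nc(-c2ccccc2O)n(-c2ccc(F)cc2)n1` gives 86.7% in a functional assay on PC-12 cells (Rattus norvegicus) for cytotoxicity, read by MTT assay, with stated times of 2 h and 24 h, tested at 5 uM (on this read-out lower numbers stand for a weaker effect and higher numbers for a stronger effect at the one concentration tested), and so holds the lowest of the two numbers measured, though its nearest neighbour compound 1 `CCc1ccc(-n2nc(-c3ccc(C(F)(F)F)cc3O)nc2-c2ccccc2O)cc1`, with 95.4%, lies within the scatter of it; the two cannot be ordered. Within the data shown here, the one step measured so far, a number 8.7 percentage points lower from compound 1 to compound 2 (within the scatter), is the only one that bears on what follows, and it stays within the scatter.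

Compound 3 `Oc1cc(C(F)(F)F)ccc1-c1nc(-c2ccccc2O)n(-c2ccc(C(F)(F)F)cc2)n1` carries the change (trifluoromethyl in place of fluoro on an aromatic carbon). The step from compound 1 to compound 2 already swapped one group at this very carbon for another without a shift beyond the scatter, so the data give no ground for a shift now; an ethyl and a fluoro both sit in the same band, and the trifluoromethyl is expected to do the same. The expected step is a number 3.3 percentage points higher from compound 2 to compound 3 (within the scatter), that is, none beyond the scatter. Compound 3 is therefore estimated at 90% in this assay, with a range from 75% to 100%.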

Compound 3, a percentage reported as activity, at one concentration (the size of the read-out at that concentration, not a potency): 90.5%
For compound 3 the middle estimate is 0.5 percentage points below the measured one; measured number inside the range.
By their numbers in this assay, from the lowest: compounds 2, 3 and 1 (each within the scatter of the next).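

In this assay, the change from 4-fluorophenyl to 4-(trifluoromethyl)phenyl gives a number 3.8 percentage points higher from compound 2 to compound 3 (within the scatter), and trifluoromethyl in place of ethyl on the same aromatic carbon gives a number 4.9 percentage points lower from compound 1 to compound 3 (within the scatter). Among these compounds, this carbon has now carried three groups, and all three pairs among compounds 1, 2 and 3 lie within the scatter, where the earlier compounds offered a single pair; even going from 1 heavy atom in fluoro to 4 heavy atoms in trifluoromethyl moves the read-out by no more than the scatter, so the three groups cannot be ordered here. No available evidence accounts for this flat result at this carbon.

Still open, on these data alone, is whether a group of another kind at this carbon, such as an amine, a carboxylic acid or a longer alkyl chain, would leave this band, and whether changes elsewhere on the shared core would do so. Each number also comes from one concentration, so the compounds shown leave open whether the three would still fall within the scatter of one another at other concentrations.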